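The source may report more compounds than this note shows. Statements on the series, on what has been measured and on what is new or still open speak of the compounds shown alone.

Of the compounds shown here, three have been read in a functional assay on RS4-11 cells (Homo sapiens) for antiproliferative activity, read by MTT assay, with a stated time of 48 h; on this read-out higher numbers stand for an effect only at larger amounts of compound and lower numbers for an effect already at smaller amounts. Compound 1 `COC(=O)c1[nH]c2cc(OC)ccc2c1-c1ccc(Cl)c(Cl)c1` gives 3800 nM. Compound 2 `COC(=O)c1[nH]c2cc(C(F)(F)F)ccc2c1-c1ccc(C(F)(F)F)cc1` gives > 100000 nM, a limit and not a number. Compound 3 `CCc1c(C(=O)OC)[nH]c2cc(OC)ccc12` gives > 100000 nM, also a limit and not a number. Compound 3 thus stands at the limit of > 100000 nM in this assay, at which 2 of the 3 values shown sit.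

Compound 4 `COC(=O)c1[nH]c2cc(OC)ccc2c1C1CCCCC1` differs from compound 3 by cyclohexyl in place of ethyl on an aromatic carbon, with cyclohexyl in place of ethyl on an aromatic carbon. Compound 1, at 3800 nM, carries a ring on that carbon. Compound 2 carries one too and still sits at a limit, so this is weak support. The expected change is an at least 5.0-fold lower number from compound 3 to compound 4 (0.69 log units; beyond the scatter), towards smaller amounts, though it may stay at the limit. Compound 4 is estimated at 20000 nM, with an expected range of 4000 nM to 100000 nM.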

Compound 4, half-maximal effective concentration: > 100000 nM
Compound 4: a limit, no number; the forecaster's own chance of this, stated with the estimate: 35%; middle value at least 5.0-fold (0.69 log units) from the limit.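

Compound 3 and compound 4 both sit at a limit and not at a number, so the step between them cannot be read. The compounds shown leave open whether cyclohexyl and ethyl differ at all on the shared core.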